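Benzyl in Place of Trifluoromethyl: Expected Cytotoxicity

This account rests on a few compounds, and the source may have more. Where it says the series, first, only, none or still open, it means among the compounds named here.

Of the compounds shown here, two share a core and have been tested in an ADME assay on Vero cells (Chlorocebus sabaeus) for cytotoxicity, with a stated time of 72 h; on this read-out lower numbers stand for stronger inhibition and higher numbers for weaker inhibition. Compound 1, `O=[N+]([O-])c1cn2c(n1)OC[C@@H](OCc1ccc(-c3ccc(OC(F)(F)F)cc3)cc1)C2`, gives a value that is a limit of the assay rather than a number: > 128000 nM. Compound 2, `O=[N+]([O-])c1cn2c(n1)OCC(COCc1ccc(OC(F)(F)F)cc1)C2`, gives 46000 nM in this assay. Within the data shown here, compound 2 thus holds the only numerical value among the two; the remaining value is a limit, as the evidence the limit of > 128000 nM in this assay, at which 1 of the 2 values shown sits, records. Among the measured compounds shown here, no step between measured compounds is available, so nothing measured shows how the change to compound 3 should play out.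

Compound 3, `O=[N+]([O-])c1cn2c(n1)OCC(COCc1ccc(OCc3ccccc3)cc1)C2`, differs from compound 2 by benzyl in place of trifluoromethyl on an oxygen on an aromatic ring. For compound 3 the change from compound 2 is expected to shift this assay by at most a small amount, a step of a 1.4-fold lower number from compound 2 to compound 3 (0.16 log units; within the scatter) that stays within the usual scatter. Compound 3 is therefore estimated at 32000 nM in this assay, with a range from 10000 nM to 128000 nM.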

Compound 3, half-maximal inhibitory concentration: 113000 nM
The estimate for compound 3 lay 3.5-fold (0.55 log units) below the measured number; the range from low to high includes it.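

Among these compounds, this pair gives the first measured step at this place, the oxygen on the aromatic ring, where the earlier compounds offered no step at all. In this assay, benzyl in place of trifluoromethyl gives a 2.5-fold higher number from compound 2 to compound 3 (0.39 log units; beyond the scatter), and since a higher number stands for weaker inhibition of the cells, the larger group, which brings a six-membered aromatic ring of its own, does not make the compound more cytotoxic here. Nothing measured here explains why the step has this size or direction.

This is a single step, so it sets no trend for other groups on that oxygen, such as plain methyl or a longer chain ending in an amine. From the compounds shown here alone, whether the same change would act alike on the longer side chain of compound 1 also stays open.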